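Adding chlorine to the benzoyl ring of compound 2

The source may hold more compounds than are shown below. What is called first, only, known or untested is meant among the compounds shown, and "the series" means these compounds.

Two compounds share one core. Compound 1 `N#C/C(=C\c1c(-c2ccccc2)[nH]c2ccccc12)S(=O)(=O)c1ccccc1` carries a phenylsulfonyl group on a chain carbon, and compound 2 `N#C/C(=C\c1c(-c2ccccc2)[nH]c2ccccc12)C(=O)c1ccccc1` carries a benzoyl group in its place. In a functional assay on MT4 cells (Homo sapiens) for antiproliferative activity, read by MTT assay, with a stated time of 96 h (a lower number here means that less compound is needed, a higher number that more compound is needed for the effect), compound 1 gives 400 nM, and compound 2 gives 500 nM. Within the data shown here, the only measured step, a 1.3-fold higher number from compound 1 to compound 2 (0.10 log units; within the scatter), lies within the scatter, so compound 2 sits on the higher of the two numbers in this assay without being separable from compound 1. Compound 3 `N#C/C(=C\c1c(-c2ccccc2)[nH]c2ccccc12)C(=O)c1ccc(Cl)cc1` differs from compound 2 by chloro in place of hydrogen on an aromatic carbon. Among the measured compounds shown here, no measured step touches this ring; the single step known, which swaps one whole group for another, shows only that altering this region moved the number little. The step expected in this assay is therefore a 1.3-fold lower number from compound 2 to compound 3 (0.10 log units; within the scatter), nothing beyond the scatter. Compound 3 is estimated at 400 nM, with a range from 150 nM to 1200 nM.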

Compound 3, half-maximal effective concentration: 400 nM
Estimate against measurement, compound 3: no gap at the digits printed, within the range that was stated.
By their numbers in this assay, from the lowest: compounds 1, 3 and 2 (each within the scatter of the next).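

In this assay the ring of the benzoyl group now has a measured step of its own: chloro in place of hydrogen, para to a large group, gives a 1.3-fold lower number from compound 2 to compound 3 (0.10 log units; within the scatter). This aromatic carbon therefore accepts a chlorine atom with no change that can be told from the scatter, something the earlier pair could not show, since it swapped one whole group for another. Replacing phenylsulfonyl with (4-chlorophenyl)carbonyl also gives no change at the digits printed from compound 1 to compound 3 (within the scatter), and no measurement at hand offers an explanation for these small steps.

A single chlorine atom cannot show whether this carbon would accept any group equally well, so an amine or a carboxylic acid in its place remains an open test. Also open, on these data alone, is what chloro would do elsewhere on this ring.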